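This account rests on a few compounds, and the source may have more. Where it says the series, first, only, none or still open, it means among the compounds named here.

Compounds measured so far:
compound 1, `COc1cccc(C(=O)Oc2ccc3c(=O)c(-c4cc(OC)c(OC)cc4OC)coc3c2)c1` — > 10000 nM
compound 2, `COc1cc(OC)c(-c2coc3cc(OCc4ccc([N+](=O)[O-])cc4)ccc3c2=O)cc1OC` — > 10000 nM

In a functional assay on A-375 cells (Homo sapiens) for antiproliferative activity, read by MTT assay, with a stated time of 24 h (a higher number here means a weaker inhibitor, a lower number a stronger inhibitor), compound 1 gives only a limit, > 10000 nM. Compound 2 likewise gives only a limit in this assay, namely > 10000 nM. The step that the two limits leave unreadable from compound 1 to compound 2 therefore cannot be read. Both values sit at the limit of > 10000 nM in this assay, at which 2 of the 2 values shown sit, so compound 2 stands at the edge of what this assay reports, with no number to place it against anything else.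

Compound 3, `COc1cc(OC)c(-c2coc3cc(OCc4ccccc4Br)ccc3c2=O)cc1OC`, differs from compound 2 by 2-bromophenyl in place of 4-nitrophenyl on a saturated chain carbon bound to an oxygen on an aromatic ring. Among the measured compounds shown here, no measured step speaks to this change; the only step available, a step that the two limits leave unreadable from compound 1 to compound 2, is left unreadable by its two limits. With compound 2 at the limit and nothing to pull the value downward, one expects compound 3 to remain weak, most probably as another limit. Compound 3 is estimated at 12000 nM in this assay, with a range from 3000 nM to 50000 nM. The expected step is a step that the limit leaves unreadable from compound 2 to compound 3.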

Compound 3, half-maximal inhibitory concentration: 2850 nM
Beside the measured number, compound 3's estimate is 4.2-fold (0.62 log units) above it, and the stated range ends above it.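

In this assay, the group on the saturated chain carbon bound to an oxygen on an aromatic ring proves able to move the result: 2-bromophenyl in place of 4-nitrophenyl gives an at least 3.5-fold lower number from compound 2 to compound 3 (0.54 log units; beyond the scatter) on an otherwise unchanged structure. 2-Bromobenzyl in place of (3-methoxyphenyl)carbonyl on the oxygen gives an at least 3.5-fold lower number from compound 1 to compound 3 (0.54 log units; beyond the scatter) and points the same way. Compound 3 is the only one of the three to return a number, while the other two values are limits: the limit of > 10000 nM in this assay, at which 2 of the 3 values shown sit.

The step between compound 1 and compound 2 cannot be read, and the two readable steps give only a minimum size. From the compounds shown here alone, it remains open whether the bromine itself, its place in 2-bromophenyl or the absence of the nitro group accounts for the difference, and what an amine or a carboxylic acid in place of the bromine would give.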